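Moving to 4-chlorobenzyl in the chlorobenzyl series

This account rests on a few compounds, and the source may have more. Where it says the series, first, only, none or still open, it means among the compounds named here.

- compound 1 `CCN(CC)Cc1ccc2nc(NC(=O)N/N=C/c3cn(Cc4ccc(C(C)(C)C)cc4)c4ccccc34)sc2c1`: 2120 nM
- compound 2 `CCN(CC)Cc1ccc2nc(NC(=O)N/N=C/c3cn(Cc4cccc(Cl)c4)c4ccccc34)sc2c1`: 2050 nM

In a functional assay on MDA-MB-231 cells (Homo sapiens) for cytotoxicity, read by MTT assay, with a stated time of 72 h (a higher number here means a weaker inhibitor, a lower number a stronger inhibitor), compound 2 gives 2050 nM, which cannot be told apart from the number for compound 1. Compound 3 `CCN(CC)Cc1ccc2nc(NC(=O)N/N=C/c3cn(Cc4ccc(Cl)cc4)c4ccccc34)sc2c1` has 4-chlorophenyl in place of 3-chlorophenyl on a saturated chain carbon bound to an aromatic nitrogen. Among the compounds with values here, only one measured step bears on this place: a 1.0-fold lower number from compound 1 to compound 2 (0.01 log units; within the scatter), where 3-chlorophenyl replaced 4-(tert-butyl)phenyl. That exchange stayed within the scatter. Within the data shown here, no measured pair isolates the change from 3-chlorobenzyl to 4-chlorobenzyl, so the evidence is thin. Even so, nothing measured points to a move in either direction. The expected result is a 1.0-fold lower number from compound 2 to compound 3 (0.01 log units; within the scatter), with no shift beyond the scatter anticipated in this assay. Compound 3 is expected at 2000 nM, with an estimated range of 1100 nM to 3600 nM.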

Compound 3, half-maximal inhibitory concentration: 2570 nM
Beside the measured number, compound 3's estimate is 1.3-fold (0.11 log units) below it; low and high end bracket the measured number.
By their numbers in this assay, from the lowest: compounds 2, 1 and 3 (each within the scatter of the next).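

In this assay, the change from 3-chlorobenzyl to 4-chlorobenzyl now has its own measured pair, giving a 1.3-fold higher number from compound 2 to compound 3 (0.10 log units; within the scatter). Within the data shown here, the exchange of tert-butyl for chloro on an aromatic carbon can also be read alone for the first time, giving a 1.2-fold higher number from compound 1 to compound 3 (0.08 log units; within the scatter). At this place, on a saturated chain carbon bound to an aromatic nitrogen, 4-(tert-butyl)phenyl, 3-chlorophenyl and 4-chlorophenyl therefore cannot be told apart in this read-out, and no further data are at hand to interpret that result.

Still open, as far as these compounds go, is whether an amine or a carboxylic acid on the phenyl ring would give a step beyond the scatter. Also open, from the compounds shown here alone, is what a longer chain in place of the saturated chain carbon would do to the number.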